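Amide-nitrogen ring swaps in the chlorophenyl isovaleramide series

This account rests on a few compounds, and the source may have more. Where it says the series, first, only, none or still open, it means among the compounds named here.

Compound 1 `CC(C)[C@H](C(=O)Nc1ncns1)c1ccc(Cl)cc1` sets the reference point: in a functional assay on CHO cells for agonist activity at Free fatty acid receptor 2 (Homo sapiens), read by cAMP accumulation (on this read-out lower numbers stand for smaller maximal responses and higher numbers for larger maximal responses), compound 1 gives 99%. Compound 2 `CC(C)[C@H](C(=O)Nc1ncc[nH]1)c1ccc(Cl)cc1` gives 55% in this assay, and compound 3 `CC(C)[C@H](C(=O)Nc1cnns1)c1ccc(Cl)cc1` gives 48%. Compound 3 therefore carries the lowest of the three numbers, although its gap to compound 2 is within the scatter; only against compound 1 does it stand clearly apart, with a number 51 percentage points lower from compound 1 to compound 3 (beyond the scatter). Both departures from the ring of compound 1 were large, a number 44 percentage points lower from compound 1 to compound 2 (beyond the scatter) and a number 51 percentage points lower from compound 1 to compound 3 (beyond the scatter), whereas a number 7 percentage points lower from compound 2 to compound 3 (within the scatter) stayed within the scatter.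

Compound 4 `CC(C)[C@H](C(=O)NC1=NC(=O)CS1)c1ccc(Cl)cc1` carries the change (a group of 6 heavy atoms (3 carbon, 1 nitrogen, 1 oxygen, 1 sulfur; one five-membered non-aromatic ring with 2 hetero atoms) in place of a group of 5 heavy atoms (2 carbon, 2 nitrogen, 1 sulfur; one five-membered aromatic ring with 3 hetero atoms), on an amide-type nitrogen). For the measured compounds named here, no measured step covers a five-membered non-aromatic ring at this position; the only guidance is that the two ring swaps away from compound 1 cut the maximal response sharply, while the swap between compound 2 and compound 3 hardly moved it. Another change of ring type is therefore expected to leave the number near the lower pair, or somewhat below it, rather than restore it. For compound 4 the estimate is 42%, with a range from 20% to 70%, which corresponds to the expected step of a number 6 percentage points lower from compound 3 to compound 4 (within the scatter).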

Compound 4, largest response reached (reported as efficacy), in percent of the reference or control that the assay uses: 96%
Compound 4: middle estimate off by 54 percentage points, on the low side, and the stated range ends below it.
By their numbers in this assay, from the lowest: compounds 3 and 2 (each within the scatter of the next); then compounds 4 and 1 (each within the scatter of the next).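

For the compounds shown here, the new ring shows that the 1,2,4-thiadiazol-5-yl group of compound 1 is not the only group on this amide-type nitrogen that gives a high maximal response in this assay: the data show a number 48 percentage points higher from compound 3 to compound 4 (beyond the scatter) and a number 41 percentage points higher from compound 2 to compound 4 (beyond the scatter), yet a number 3 percentage points lower from compound 1 to compound 4 (within the scatter). An aromatic five-membered ring is therefore not required at this position, and having one does not settle the outcome, since compound 1 sits with non-aromatic compound 4 while aromatic compound 2 and compound 3 form the lower pair. No available data bear on what separates these two pairs.

As far as these compounds go, it remains open whether the high response extends to other non-aromatic rings or is particular to the ring of compound 4. From the compounds shown here alone, it is also open how an oxazole or a carboxylic acid would behave on this nitrogen, and whether the pattern of the four rings would hold with a longer chain on the shared core.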